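The source may hold more compounds than are shown below. What is called first, only, known or untested is meant among the compounds shown, and "the series" means these compounds.

Compound 1 `CSc1ccccc1CSc1nc(-c2ccc(F)cc2)c(-c2ccncc2)[nH]1`: 6700 nM
Compound 2 `C[S+]([O-])c1ccc(CCSc2nc(-c3ccc(F)cc3)c(-c3ccncc3)[nH]2)cc1`: 500 nM

In a functional assay (Homo sapiens) for inhibition (on this read-out higher numbers stand for weaker inhibition and lower numbers for stronger inhibition), compound 2 has the lower of the two numbers, meaning the stronger inhibition. Compound 3 `CSc1cc(CSc2nc(-c3ccc(F)cc3)c(-c3ccncc3)[nH]2)ccc1O` alters one group of compound 2: a group of 9 heavy atoms (7 carbon, 1 oxygen, 1 sulfur; one six-membered aromatic ring of carbon only) in place of a group of 10 heavy atoms (8 carbon, 1 oxygen, 1 sulfur; one six-membered aromatic ring of carbon only), on a saturated chain carbon bound to a sulfur. The new group is 4-hydroxy-3-(methylsulfanyl)phenyl, on a saturated chain carbon bound to a sulfur. Going by the values given here, one measured step bears on this, a large one at the same place: a 13-fold lower number from compound 1 to compound 2 (1.13 log units; beyond the scatter). It shows that a swap here can move the number far, but it cannot predict this new group. A partial return toward compound 1 at 6700 nM seems likeliest. The expected change is a 3.0-fold higher number from compound 2 to compound 3 (0.48 log units; beyond the scatter), a smaller step toward weaker inhibition. Compound 3 is estimated at 1500 nM, with an expected range of 300 nM to 7000 nM.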

Compound 3, half-maximal inhibitory concentration: 280 nM
Estimate against measurement, compound 3: 5.4-fold (0.73 log units) above; measured number below the stated range.
By their numbers in this assay, from the lowest: compounds 3 and 2 (each within the scatter of the next); then compound 1.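

In this assay the new 4-hydroxy-3-(methylsulfanyl)phenyl group gives a 1.8-fold lower number from compound 2 to compound 3 (0.25 log units; within the scatter), so it cannot be ranked against the group of compound 2. Against 2-(methylsulfanyl)phenyl, the same group gives a 24-fold lower number from compound 1 to compound 3 (1.38 log units; beyond the scatter), so a methylsulfanyl on the ring at this place does not alone set the number. No measurement here explains the difference.

The compounds shown leave open whether the hydroxy group matters without the methylsulfanyl, and how an amine or a carboxylic acid on this ring would read.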